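A few compounds are considered here, and "the series" means these few. Any claim that something is new, unique, unknown or untested is made for them only; others in the source may bear on it.

Compound 1 `CC(CCc1cccc(OCc2ccc3ccccc3n2)c1)Cc1nnn[nH]1` is the reference here. In an assay on membranes from lung (Cavia porcellus) for binding affinity to cysteinyl leukotriene receptor (Homo sapiens) (on this read-out lower numbers stand for stronger inhibition and higher numbers for weaker inhibition), compound 1 gives 17 nM, the lowest of the two numbers measured. Compound 2 `CC(CCC(=O)O)Cc1ccc(OCc2ccc3ccccc3n2)cc1` has a carboxylic acid instead of the tetrazole ring, and in this assay compound 2 gives 43 nM, a weaker result beyond the usual scatter. Compound 3 `CC(Cc1cccc(OCc2ccc3ccccc3n2)c1)CC(C)C(=O)O` differs from compound 1 as follows: 3-carboxy-1-methylbutyl in place of 2-((1H-tetrazol-5-yl)methyl)propyl on a saturated chain carbon bound to an aromatic carbon. Since compound 2 with its acid already shows 43 nM, a small loss is expected, a step from a 2.1-fold higher number from compound 1 to compound 3 (0.31 log units; beyond the scatter) within or just beyond the scatter. Compound 3 is therefore estimated at 35 nM, with a range from 12 nM to 100 nM.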

Compound 3, inhibition constant: 24 nM
Estimate against measurement, compound 3: 1.5-fold (0.16 log units) above, and the stated range covers the measured number.
By their numbers in this assay, from the lowest: compounds 1, 3 and 2 (each within the scatter of the next, the first and the last beyond it).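

In this assay, 3-carboxy-1-methylbutyl can take the place of 2-((1H-tetrazol-5-yl)methyl)propyl on a saturated chain carbon bound to an aromatic carbon with only a 1.4-fold higher number from compound 1 to compound 3 (0.15 log units; within the scatter) as the result. At this place, then, a chain ending in a carboxylic acid and with no ring serves as well as the tetrazole group. Nothing at hand explains this result.

On these data alone, since the whole group changes in one step, the contribution of its separate parts stays open. So does whether a chain ending in a primary amide or a hydroxyl would give a similar number.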